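Thiourea aryl swap on a pyridyloxy-phenyl scaffold

The compounds below may be only part of what the source reports. "The series", "measured", "known", "first", "only" and "open" are said of these compounds alone.

Compound 1 `CNC(=O)c1ccc(Oc2cccc(NC(=S)Nc3ccc(F)c(F)c3)c2)nc1`: 26700 nM
Compound 2 `CNC(=O)c1ccc(Oc2cccc(NC(=S)Nc3cccc(C(F)(F)F)c3)c2)nc1`: 23300 nM

Compound 1 and compound 2 were both tested in a functional assay on HepG2 cells (Homo sapiens) for antiproliferative activity, read by MTT assay; on this read-out higher numbers stand for weaker inhibition and lower numbers for stronger inhibition. On the numbers shown, compound 2 gives the lower of the two, though the step of a 1.1-fold lower number from compound 1 to compound 2 (0.06 log units; within the scatter) lies within the scatter, so the two compounds cannot be told apart on this read-out. Compound 3 `CNC(=O)c1ccc(Oc2cccc(NC(=S)Nc3ccc(Cl)cc3Cl)c2)nc1` has not yet been measured in this assay. It differs from compound 2 in one place: 2,4-dichlorophenyl in place of 3-(trifluoromethyl)phenyl on an amide-type nitrogen. Going by the values given here, the only measured step that bears on this position is the one from compound 1 to compound 2, where one substituted phenyl replaced another on the same amide-type nitrogen, and that step stayed within the scatter. From this single comparison, compound 3 is expected to give a number close to that of compound 2, with no step beyond the scatter, a 1.1-fold lower number from compound 2 to compound 3 (0.02 log units; within the scatter). The estimate for compound 3 in this assay is 22000 nM, with a range from 8000 nM to 60000 nM.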

Compound 3, half-maximal inhibitory concentration: 21600 nM
Compound 3: the middle estimate sits 1.0-fold (0.01 log units) above what was measured; the measured number falls inside the stated range.
By their numbers in this assay, from the lowest: compounds 3, 2 and 1 (each within the scatter of the next).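

With a chlorine-bearing ring at this place, the picture from the two fluorine-bearing rings holds in this assay: 2,4-dichlorophenyl on the amide-type nitrogen gives a 1.1-fold lower number from compound 2 to compound 3 (0.03 log units; within the scatter), and a 1.2-fold lower number from compound 1 to compound 3 (0.09 log units; within the scatter). Neither step leaves the scatter, so compound 1, compound 2 and compound 3 cannot be told apart on this read-out. Across these three substituted phenyl groups, the exchange of fluorine or trifluoromethyl for two chlorine atoms thus produces no difference that can be read.

Still open, as far as these compounds go, is whether a phenyl carrying an amine or a carboxylic acid, or a longer alkyl chain in place of the phenyl, would give a step beyond the scatter at this nitrogen. Nothing at hand bears on why the three values lie so close together.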